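Aryl swap on the shared core: compound 2 to compound 3

This account rests on a few compounds, and the source may have more. Where it says the series, first, only, none or still open, it means among the compounds named here.

Two compounds of the series have numbers in a functional assay on A549 cells (Homo sapiens) for antiproliferative activity, read by MTT assay, with a stated time of 72 h; on this read-out lower numbers stand for stronger inhibition and higher numbers for weaker inhibition. Compound 1 `O=C(Nc1ccc(Oc2ccnc3[nH]ccc23)cc1)c1cc2cccnc2n(-c2ccc(Cl)cc2)c1=O` gives 290 nM in this assay, and compound 2 `Cn1ccc2c(Oc3ccc(NC(=O)c4cc5cccnc5n(-c5ccc(Cl)cc5)c4=O)cc3)ccnc21` gives 630 nM. For the measured compounds named here, the only measured step, a 2.2-fold higher number from compound 1 to compound 2 (0.34 log units; beyond the scatter), is a modest rise beyond the scatter and concerns a methyl in place of hydrogen on an aromatic nitrogen. Compound 2 therefore stands at the higher of the two numbers, with compound 1 the nearer and lower of the pair.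

Compound 3 `Cn1ccc2c(Oc3ccc(NC(=O)c4cc5cccnc5n(-c5ccc(Br)cc5F)c4=O)cc3)ccnc21` is not yet measured. It differs from compound 2 in one place: 4-bromo-2-fluorophenyl in place of 4-chlorophenyl on an aromatic nitrogen. Going by the values given here, no measured step in this assay touches this aromatic nitrogen or the group carried on it, so there is no step that bears directly on this change; the single step available concerns a different site.

With nothing to lean on, the expectation for compound 3 in this assay is a number close to that of compound 2, and no step beyond the scatter, which means an estimated step of a 1.1-fold lower number from compound 2 to compound 3 (0.02 log units; within the scatter). The estimate for compound 3 is 600 nM, expected to lie between 250 nM and 1500 nM.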

Compound 3, half-maximal inhibitory concentration: 1630 nM
For compound 3 the middle estimate is 2.7-fold (0.43 log units) below the measured one; measured number above the stated range.
By their numbers in this assay, from the lowest: compound 1; then compound 2; then compound 3.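

In this assay, the group on the aromatic nitrogen of the shared core proves able to move the number: 4-bromo-2-fluorophenyl in place of 4-chlorophenyl gives a 2.6-fold higher number from compound 2 to compound 3 (0.41 log units; beyond the scatter), a modest step but one beyond the scatter, and the only reading on this position among the compounds shown. The swap alters the aryl ring in two respects at once, with bromine where the chlorine stood and a fluorine added, so this single step cannot be divided between the two. Nothing available bears on what lies behind the rise.

From the compounds shown here alone, it remains open whether the bromine or the fluorine carries the step, which a phenyl ring bearing only one of these halogens would help to separate, and whether an unsubstituted phenyl, a ring carrying a methoxy group or a simple alkyl chain on the same nitrogen would follow the same direction. Also open, going by these compounds, is whether the same aryl swap gives a similar step on the core of compound 1, which keeps the hydrogen on the aromatic nitrogen that compound 2 replaces with methyl.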